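Swapping acetyl for methoxy on a styryl piperidine

A few compounds are considered here, and "the series" means these few. Any claim that something is new, unique, unknown or untested is made for them only; others in the source may bear on it.

Measured so far:
Compound 1, `CN1CCCC[C@H]1/C=C/c1ccc(O)cc1`, in a functional assay on MCF7 cells (Homo sapiens) for inhibition, read by MTT assay, with a stated time of 24 h (on this read-out lower numbers stand for stronger inhibition and higher numbers for weaker inhibition), compound 1 gives 1.51 ug/mL.
Compound 2, `Cc1cccc(C)c1/C=C/[C@@H]1CCCCN1`, in this assay compound 2 gives 4.29 ug/mL.
Compound 3, `CC(=O)c1ccc(/C=C/[C@@H]2CCCCN2)cc1`, in this assay compound 3 gives 2.7 ug/mL.

Of these three numbers, compound 3 has the second highest, but its gaps to compound 2 and to compound 1 both lie within the scatter, so no ranking among them can be claimed. The next compound, compound 4, `COc1ccc(/C=C/[C@@H]2CCCCN2)cc1`, differs from compound 3 in one place: methoxy in place of acetyl on an aromatic carbon. For the measured compounds named here, no pair of measured compounds separates this change on its own, so nothing measured guides its size. The step of a 1.1-fold lower number from compound 3 to compound 4 (0.03 log units; within the scatter) is expected to stay within the scatter. Compound 4 is therefore estimated at 2.5 ug/mL, with a range from 1 ug/mL to 6 ug/mL.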

Compound 4, half-maximal inhibitory concentration: 3.57 ug/mL
Estimate against measurement, compound 4: 1.4-fold (0.15 log units) below; the measured number falls inside the stated range.
By their numbers in this assay, from the lowest: compounds 1, 3, 4 and 2 (each within the scatter of the next, the first and the last beyond it).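

In this assay the swap of acetyl for methoxy on an aromatic carbon gives a 1.3-fold higher number from compound 3 to compound 4 (0.12 log units; within the scatter) and so stays within the usual scatter. For the compounds shown here, this is the first measured pair that differs in one place, and at this position it separates the two groups by no more than repeat measurements would. Nothing at hand bears on why the number holds here.

Compound 1 differs from both in more than one place, so it does not extend this comparison. From the compounds shown here alone, whether an amine or a carboxylic acid at this carbon would go beyond the scatter remains open.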